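The source may hold more compounds than are shown below. What is called first, only, known or untested is meant among the compounds shown, and "the series" means these compounds.

Series notes. Compound 1 `COc1ccc(CN(C(=O)CSc2nc3ccc(OC)cc3s2)c2cc(OC)c(OC)c(OC)c2)cc1` is the reference point; in a functional assay on MGC-803 cells (Homo sapiens) for antiproliferative activity, read by MTT assay, with a stated time of 48 h (on this read-out lower numbers stand for stronger inhibition and higher numbers for weaker inhibition), compound 1 gives 1270 nM. Among the three measured compounds, compound 1 stands second highest. Compound 3 `COc1ccc(CN(C(=O)CSc2nc3ccccc3[nH]2)c2cc(OC)c(OC)c(OC)c2)cc1` gives 1230 nM in this assay, and compound 2 `COc1ccc(CN(C(=O)CSc2nnnn2C)c2cc(OC)c(OC)c(OC)c2)cc1` gives 2490 nM in this assay. The steps of a 1.0-fold lower number from compound 1 to compound 3 (0.01 log units; within the scatter) and a 2.0-fold higher number from compound 1 to compound 2 (0.29 log units; within the scatter) both remain within the scatter, whereas a 2.0-fold lower number from compound 2 to compound 3 (0.31 log units; beyond the scatter) reaches beyond it.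

Compound 4 `COc1ccc(CN(C(=O)CSc2nncs2)c2cc(OC)c(OC)c(OC)c2)cc1` is not yet measured. Its change from compound 1 is 1,3,4-thiadiazol-2-yl in place of 6-methoxy-1,3-benzothiazol-2-yl on a sulfur. For the measured compounds named here, the steps that bear on it replace the same group on the same sulfur: a 1.0-fold lower number from compound 1 to compound 3 (0.01 log units; within the scatter), where another bicyclic ring enters, and a 2.0-fold higher number from compound 1 to compound 2 (0.29 log units; within the scatter), where a single five-membered aromatic ring enters. The incoming 1,3,4-thiadiazol-2-yl shares with the 1-methyl-1H-tetrazol-5-yl of compound 2 a single five-membered aromatic ring and no second ring, so the step toward compound 2 is taken as the closer guide. A modest move toward a higher number, at about the edge of the scatter, is expected, a 1.6-fold higher number from compound 1 to compound 4 (0.20 log units; within the scatter). For compound 4 the expected value in this assay is 2000 nM, with a range from 1000 nM to 4000 nM.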

Compound 4, half-maximal inhibitory concentration: 1150 nM
For compound 4 the middle estimate is 1.7-fold (0.24 log units) above the measured one; low and high end bracket the measured number.
By their numbers in this assay, from the lowest: compounds 4, 3, 1 and 2 (each within the scatter of the next, the first and the last beyond it).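

In this assay, the 6-methoxy-1,3-benzothiazol-2-yl on this sulfur can give way to a much smaller single ring with no clear change in the number: the step is a 1.1-fold lower number from compound 1 to compound 4 (0.04 log units; within the scatter) and the two bicyclic groups are therefore not set apart from 1,3,4-thiadiazol-2-yl, with the comparison to the 1H-benzimidazol-2-yl being a 1.1-fold lower number from compound 3 to compound 4 (0.03 log units; within the scatter) in the same assay. Compound 4 also shows that having a single five-membered aromatic ring on the sulfur does not by itself fix the number: the comparison with the other such ring is a 2.2-fold lower number from compound 2 to compound 4 (0.34 log units; beyond the scatter) and this modest step, beyond the scatter, places compound 2 against any reading that smaller groups here give higher numbers. Nothing measured on these compounds accounts for the gap between the two single rings, so it stands as an observation only.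

Compounds 2 and 4 differ in both the ring atoms and the methyl group, and the unsubstituted 1H-tetrazol-5-yl would be needed to separate the two. Also open, from the compounds shown here alone, is how the number responds when the sulfur carries no aromatic ring at all, as with a longer chain, an amine or a carboxylic acid.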